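Lengthening an Aromatic Substituent in a Urea Series

A few compounds are considered here, and "the series" means these few. Any claim that something is new, unique, unknown or untested is made for them only; others in the source may bear on it.

Going by the values given here, compound 2 `Cc1ccccc1NC(=O)NCC1(c2ccccc2)CCCCC1` gives 640 nM in an assay on microsomes from intestine for inhibition of acyl-CoA:cholesterol acyltransferase (Oryctolagus cuniculus) (on this read-out lower numbers stand for stronger inhibition and higher numbers for weaker inhibition), the lower of the two numbers measured so far; compound 1 `O=C(NCC1(c2ccccc2)CCCCC1)Nc1ccccc1` gives 2300 nM. Among the compounds with values here, the only measured step, a 3.6-fold lower number from compound 1 to compound 2 (0.56 log units; beyond the scatter), came from putting a methyl group on an aromatic carbon. Compound 3 `CC(C)c1ccccc1NC(=O)NCC1(c2ccccc2)CCCCC1` takes the same place one size further: isopropyl in place of methyl on an aromatic carbon. Within the data shown here, only that single step bears on it, and it was modest, so a further modest lowering in this assay is expected rather than a large one. Compound 3 is therefore expected to give 300 nM, within 100 nM to 1000 nM, an expected step of a 2.1-fold lower number from compound 2 to compound 3 (0.33 log units; beyond the scatter).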

Compound 3, half-maximal inhibitory concentration: 390 nM
Compound 3: the middle estimate sits 1.3-fold (0.11 log units) below what was measured; low and high end bracket the measured number.
By their numbers in this assay, from the lowest: compounds 3 and 2 (each within the scatter of the next); then compound 1.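

In this assay, isopropyl in place of methyl gives a 1.6-fold lower number from compound 2 to compound 3 (0.22 log units; within the scatter), so the larger group cannot be told apart from methyl at this position. Measured against hydrogen, isopropyl gives a 5.9-fold lower number from compound 1 to compound 3 (0.77 log units; beyond the scatter), so having a group on this aromatic carbon still matters, while the added size shows no clear further change. Nothing measured here explains these numbers. Still open, from the compounds shown here alone, is whether a longer chain, a methoxy group or a chlorine on this same carbon would behave like methyl and isopropyl, or would give a clearly different number.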